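A few compounds are considered here, and "the series" means these few. Any claim that something is new, unique, unknown or untested is made for them only; others in the source may bear on it.

Compound 1 `CC(C)n1nc(-c2cc(C(C)(C)C)on2)c2c(N)ncnc21`: 210 nM
Compound 2 `CC(C)(O)Cn1nc(-c2cc(C3CC3)on2)c2c(N)ncnc21`: 68 nM
Compound 3 `CC(C)n1nc(/C=N/OCc2ccccc2)c2c(N)ncnc21`: 8330 nM

Of the compounds shown here, three built on a shared core have been tested in an assay on isolated protein for inhibition of proto-oncogene tyrosine-protein kinase receptor Ret (Homo sapiens), read by radiometric assay and 33P incorporation, in the presence of a further agent that is not named here; a higher number here means a weaker inhibitor, a lower number a stronger inhibitor. Compound 1 gives 210 nM, the second highest of the three numbers. Its nearest neighbour is compound 2, which gives 68 nM, a lower number that lies beyond the usual scatter of repeated measurements. The furthest is compound 3, which gives 8330 nM, a far higher number, also well beyond the scatter. Compound 2 differs from compound 1 in more than one place, and compound 3 lacks the five-membered ring altogether, so neither pair isolates a single structural change.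

Compound 4 `CCc1cc(-c2nn(C(C)C)c3ncnc(N)c23)no1` has not yet been measured. It differs from compound 1 in one place: ethyl in place of tert-butyl on an aromatic carbon, in words ethyl in place of tert-butyl on an aromatic carbon. Among the compounds with values here, no measured pair shows this exact change, so the size of the step can only be guessed. A small step is expected, probably towards a somewhat higher number, although a step within the scatter would not be surprising. The estimated step is a 1.5-fold higher number from compound 1 to compound 4 (0.18 log units; within the scatter). Compound 4 is expected to give about 320 nM in this assay, with a likely range from 100 nM to 1000 nM.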

Compound 4, half-maximal inhibitory concentration: 41 nM
For compound 4 the middle estimate is 7.8-fold (0.89 log units) above the measured one, outside the stated range (below it).
By their numbers in this assay, from the lowest: compounds 4 and 2 (each within the scatter of the next); then compound 1; then compound 3.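

Within the data shown here, the step from tert-butyl to ethyl is the first change in one place in this set, and in this assay it gives a 5.1-fold lower number from compound 1 to compound 4 (0.71 log units; beyond the scatter), so the group on this aromatic carbon, next to the ring oxygen, clearly affects the read-out. Among the features counted here, the two groups differ only in size: the tert-butyl has 4 heavy atoms and the ethyl has 2, all carbon, with no ring, hydrogen-bond donors, hydrogen-bond acceptors or net charge in either, and in this one pair the smaller group goes with the lower number. No measurement at hand explains the step.

A single pair cannot show whether the number keeps falling as the group shrinks, so methyl or a bare hydrogen at this position could fall on either side of the ethyl, and a straight propyl chain or a group carrying an amine remains an open case. As far as these compounds go, it also remains open whether the same swap would give a step of similar size with a different group on the ring nitrogen of the shared core.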